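Difluorobenzyl isomer step from compound 3 to compound 4

The source may report more compounds than this note shows. Statements on the series, on what has been measured and on what is new or still open speak of the compounds shown alone.

Measured in a functional assay on Bel-7402 cells (Homo sapiens) for antiproliferative activity, read by MTT assay, with a stated time of 72 h; a lower number here means a stronger inhibitor, a higher number a weaker inhibitor:
- compound 1 `C=C1C(=O)O[C@H]2[C@H]1CC/C(COC(=O)Cn1cc(F)c(=O)n(Cc3ccccc3)c1=O)=C\CC[C@@]1(C)O[C@@H]21`: 3980 nM
- compound 2 `C=C1C(=O)O[C@H]2[C@H]1CC/C(COC(=O)Cn1cc(F)c(=O)n(Cc3ccc([N+](=O)[O-])cc3)c1=O)=C\CC[C@@]1(C)O[C@@H]21`: 4070 nM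
- compound 3 `C=C1C(=O)O[C@H]2[C@H]1CC/C(COC(=O)Cn1cc(F)c(=O)n(Cc3ccc(F)cc3F)c1=O)=C\CC[C@@]1(C)O[C@@H]21`: 3670 nM

Compound 3 sits within the scatter of both other compounds. The steps reaching it are small: a 1.1-fold lower number from compound 1 to compound 3 (0.04 log units; within the scatter) and a 1.1-fold lower number from compound 2 to compound 3 (0.04 log units; within the scatter). Compound 4 `C=C1C(=O)O[C@H]2[C@H]1CC/C(COC(=O)Cn1cc(F)c(=O)n(Cc3ccc(F)c(F)c3)c1=O)=C\CC[C@@]1(C)O[C@@H]21` differs from it as follows: 3,4-difluorophenyl in place of 2,4-difluorophenyl on a saturated chain carbon bound to an aromatic nitrogen. In words, this is 3,4-difluorophenyl in place of 2,4-difluorophenyl on a saturated chain carbon bound to an aromatic nitrogen. The other aryl change measured, a 1.0-fold higher number from compound 1 to compound 2 (0.01 log units; within the scatter), is equally small. No step beyond the scatter is therefore expected in this assay, in either direction. The estimated change is a 1.0-fold higher number from compound 3 to compound 4 (0.02 log units; within the scatter). Compound 4 is expected at 3800 nM. The estimated range for this value runs from 2200 nM to 6500 nM.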

Compound 4, half-maximal inhibitory concentration: 2700 nM
Estimate against measurement, compound 4: 1.4-fold (0.15 log units) above; measured number inside the range.
By their numbers in this assay, from the lowest: compounds 4, 3, 1 and 2 (each within the scatter of the next).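

With 3,4-difluorophenyl in place of 2,4-difluorophenyl on the saturated chain carbon bound to an aromatic nitrogen, the reading in this assay stays within the scatter (a 1.4-fold lower number from compound 3 to compound 4 (0.13 log units; within the scatter)). The steps from the other two aryl groups also stay within it (a 1.5-fold lower number from compound 2 to compound 4 (0.18 log units; within the scatter); a 1.5-fold lower number from compound 1 to compound 4 (0.17 log units; within the scatter)), so all four aryl groups shown give numbers that cannot be told apart. Nothing available explains this flat response. Open, as far as these compounds go, is whether an amine, a carboxylic acid or a longer chain at this place would give a step beyond the scatter.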